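This account rests on a few compounds, and the source may have more. Where it says the series, first, only, none or still open, it means among the compounds named here.

Measured compounds:
- compound 1 `CC(C)C(c1ccc(-c2ccc3cccc(F)c3c2)[nH]c1=O)N1CCNC1=O`: 24900 nM
- compound 2 `CC(C)C(/C=C1\CCNC1=O)c1ccc(-c2ccc3cccc(F)c3c2)[nH]c1=O`: 20700 nM

In a physicochemical assay for solubility, in phosphate buffer, measured as kinetic solubility (on this read-out higher numbers stand for higher solubility and lower numbers for lower solubility), compound 2 stands at the lowest of the two numbers, with compound 1 nearest; the gap between them is a 1.2-fold lower number from compound 1 to compound 2 (0.08 log units; within the scatter), so the two compounds cannot be told apart on this read-out. Compound 3 `CC(C)C(c1ccc(-c2ccc3cccc(F)c3c2)[nH]c1=O)N1CCN/C1=N\C#N` has not been measured yet. It differs from compound 2 in one place: a group of 8 heavy atoms (4 carbon, 4 nitrogen; one five-membered non-aromatic ring with 2 hetero atoms) in place of a group of 7 heavy atoms (5 carbon, 1 nitrogen, 1 oxygen; one five-membered non-aromatic ring with 1 hetero atom), on a saturated chain carbon bound to an aromatic carbon and a saturated chain carbon. For the measured compounds named here, the only measured step, from compound 1 to compound 2, is the one that bears on this change, since it also swaps the group on that same saturated chain carbon, and it was a 1.2-fold lower number from compound 1 to compound 2 (0.08 log units; within the scatter). With one step of that size and no other guide, no shift beyond the scatter is expected in this assay, and the step to compound 3 is estimated as a 1.2-fold higher number from compound 2 to compound 3 (0.08 log units; within the scatter). Compound 3 is therefore expected to give about 25000 nM, in a range from 12000 nM to 50000 nM.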

Compound 3, solubility: 25200 nM
Estimate against measurement, compound 3: 1.0-fold (0.00 log units) below; measured number inside the range.
By their numbers in this assay, from the lowest: compounds 2, 1 and 3 (each within the scatter of the next).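

At the saturated chain carbon bound to an aromatic carbon and a saturated chain carbon, a third five-membered non-aromatic ring group has now been read in this assay, and both a 1.2-fold higher number from compound 2 to compound 3 (0.09 log units; within the scatter) and a 1.0-fold higher number from compound 1 to compound 3 (0.01 log units; within the scatter) lie within the scatter. This position has therefore taken a group of 8 heavy atoms with a triple bond and no oxygen, and compounds 1, 2 and 3 still cannot be told apart on this read-out. Nothing measured here explains this result.

On these data alone, all three groups are five-membered rings with no net charge, so it remains open whether a primary amine, a carboxylic acid or an open alkyl chain on this same carbon would give a step beyond the scatter. Changes elsewhere on the shared core also remain open.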